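Indole in place of acetoxy-methoxyphenyl on the hydrazone carbon

The source may report more compounds than this note shows. Statements on the series, on what has been measured and on what is new or still open speak of the compounds shown alone.

Measured compounds:
compound 1 `O=C(CCN1CCN(c2ccnc3cc(Cl)ccc23)CC1)N/N=C/c1ccccc1` — 300 nM
compound 2 `O=C(CCN1CCN(c2ccnc3cc(Cl)ccc23)CC1)N/N=C/c1ccc(Cl)cc1` — 200 nM
compound 3 `COc1cc(/C=N/NC(=O)CCN2CCN(c3ccnc4cc(Cl)ccc34)CC2)ccc1OC(C)=O` — 15800 nM

In an ADME assay on cells (Splenocyte, Mus musculus, strain BALB/c) for cytotoxicity, read by thymidine incorporation, with a stated time of 24 h (on this read-out lower numbers stand for stronger inhibition and higher numbers for weaker inhibition), compound 3 gives the highest of the three numbers; the nearest is compound 1, and the gap to compound 2 is wider still. Both steps into it are large: a 53-fold higher number from compound 1 to compound 3 (1.72 log units; beyond the scatter) and a 79-fold higher number from compound 2 to compound 3 (1.90 log units; beyond the scatter), whereas a 1.5-fold lower number from compound 1 to compound 2 (0.18 log units; within the scatter). Compound 4 `O=C(CCN1CCN(c2ccnc3cc(Cl)ccc23)CC1)N/N=C/c1c[nH]c2ccccc12` has not yet been measured in this assay. Its change from compound 3 is 1H-indol-3-yl in place of 4-acetoxy-3-methoxyphenyl on a carbon with a double bond to nitrogen. Among the compounds with values here, no measured step involves the 1H-indol-3-yl group, so nothing speaks directly to it. Within the data shown here, what the data do show is that the 4-acetoxy-3-methoxyphenyl group that leaves is the one feature setting compound 3 apart from compound 1 and compound 2, and its removal is therefore expected to bring the number back down, with an expected step of a 16-fold lower number from compound 3 to compound 4 (1.20 log units; beyond the scatter). Among the measured compounds shown here, the group that enters is new, and no step tells how it will behave. The estimate for compound 4 is held wide: 1000 nM, in the range 150 nM to 8000 nM.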

Compound 4, half-maximal inhibitory concentration: 5700 nM
Estimate against measurement, compound 4: 5.7-fold (0.76 log units) below, within the range that was stated.
By their numbers in this assay, from the lowest: compounds 2 and 1 (each within the scatter of the next); then compound 4; then compound 3.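

In this assay, 1H-indol-3-yl in place of 4-acetoxy-3-methoxyphenyl on the carbon with a double bond to nitrogen gives only a 2.8-fold lower number from compound 3 to compound 4 (0.44 log units; beyond the scatter) and does not bring the number back to those of compound 1 and compound 2. The steps of a 19-fold higher number from compound 1 to compound 4 (1.28 log units; beyond the scatter) and a 29-fold higher number from compound 2 to compound 4 (1.45 log units; beyond the scatter) show that the high numbers at this position are not confined to the 4-acetoxy-3-methoxyphenyl group, since a group without acetoxy or methoxy also lies far from phenyl and 4-chlorophenyl. No measurement is available that explains these differences.

The compounds shown leave open how a phenyl carrying a free hydroxyl, an amine or a carboxylic acid would read at this position. They also leave open whether the acetoxy or the methoxy of compound 3 counts for more in its step from compound 1.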